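A few compounds are considered here, and "the series" means these few. Any claim that something is new, unique, unknown or untested is made for them only; others in the source may bear on it.

In a functional assay on HeLa cells (Homo sapiens) for inhibition, read by trypan blue exclusion, with a stated time of 72 h (on this read-out lower numbers stand for stronger inhibition of growth and higher numbers for weaker inhibition of growth), compound 1 (`CC/C(=C(\c1ccc(NC(=O)C(C)C)cc1)c1ccc(OC)cc1)c1ccccc1`) gives 10100 nM, compound 2 (`CC/C(=C(\c1ccc(NC(=O)C(C)C)cc1)c1ccc(OC)cc1)c1ccc(O)cc1`) gives 3700 nM and compound 3 (`CC/C(=C(\c1ccc(NC(=O)C(C)C)cc1)c1ccc(OC)cc1)c1ccc(Cl)cc1Cl`) gives 5500 nM. Compound 3 sits within the scatter of both others, as a 1.8-fold lower number from compound 1 to compound 3 (0.26 log units; within the scatter) and a 1.5-fold higher number from compound 2 to compound 3 (0.17 log units; within the scatter) show. Compound 4 (`CC/C(=C(/c1ccc(O)cc1)c1ccc(NC(=O)C(C)C)cc1)c1ccc(Cl)cc1Cl`) alters compound 3 at one place, with hydrogen in place of methyl on an oxygen on an aromatic ring. Within the data shown here, no measured step makes this exact change. The closest guide is the hydroxy gained elsewhere in a 2.7-fold lower number from compound 1 to compound 2 (0.44 log units; beyond the scatter), a modest step that lies beyond the scatter. The expected step is a 1.7-fold lower number from compound 3 to compound 4 (0.24 log units; within the scatter), a small move towards a lower number that may not clear the scatter. The estimate for compound 4 is 3200 nM, with an expected range of 1300 nM to 7500 nM.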

Compound 4, concentration for 50% growth inhibition: 20300 nM
For compound 4 the middle estimate is 6.3-fold (0.80 log units) below the measured one; measured number above the stated range.
By their numbers in this assay, from the lowest: compounds 2, 3, 1 and 4 (each within the scatter of the next, the first and the last beyond it).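

In this assay, hydroxy in place of methoxy at this place weakens growth inhibition (a 3.7-fold higher number from compound 3 to compound 4 (0.57 log units; beyond the scatter)). The hydroxy gained elsewhere moved the number the other way (a 2.7-fold lower number from compound 1 to compound 2 (0.44 log units; beyond the scatter)), so adding a hydroxy does not have the same outcome at every place on these compounds. No measurement shown here explains this difference. Still open, going by these compounds, is how an ethoxy group or an amine would compare at this place, and whether the same change would raise the number with phenyl in place of 2,4-dichlorophenyl.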